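Cyclobutyl in Place of Cyclopropyl on the Shared Core

A few compounds are considered here, and "the series" means these few. Any claim that something is new, unique, unknown or untested is made for them only; others in the source may bear on it.

In a functional assay on CCRF-CEM cells (Homo sapiens) for cytotoxicity, with a stated time of 72 h (a lower number here means a stronger inhibitor, a higher number a weaker inhibitor), compound 3 `OC[C@H]1O[C@@H](n2cnc3c(C4CC4)ncnc32)[C@H](O)[C@@H]1O`, which carries cyclopropyl, gives 1000 nM, the lowest number in this small set. Compound 1 `CCCCc1ncnc2c1ncn2[C@@H]1O[C@H](CO)[C@@H](O)[C@H]1O`, which carries butyl at the same place, gives 49000 nM. Compound 2 `CC(C)Cc1ncnc2c1ncn2[C@@H]1O[C@H](CO)[C@@H](O)[C@H]1O`, which carries isobutyl there, is recorded only as a limit, > 130000 nM. Replacing the open chain with cyclopropyl therefore produced large steps, a 49-fold lower number from compound 1 to compound 3 (1.69 log units; beyond the scatter) and an at least 130-fold lower number from compound 2 to compound 3 (2.11 log units; beyond the scatter). Branching the chain produced a smaller one, an at least 2.6-fold higher number from compound 1 to compound 2 (0.42 log units; beyond the scatter).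

Compound 4 `OC[C@H]1O[C@@H](n2cnc3c(C4CCC4)ncnc32)[C@H](O)[C@@H]1O` changes the group once more: cyclobutyl in place of cyclopropyl on an aromatic carbon. The cyclobutyl sits on an aromatic carbon of the six-membered aromatic ring, and the rest of the structure is that of compound 3. Going by the values given here, no measured step compares one ring with another, so these steps bear on the change only indirectly. Cyclobutyl keeps a ring, which all the low numbers here share only through compound 3 at 1000 nM, while compound 1 at 49000 nM marks how far an open chain lies above it. A moderate rise is therefore expected in this assay, much smaller than the large steps to the open chains. The expected change is a 4.0-fold higher number from compound 3 to compound 4 (0.60 log units; beyond the scatter). For compound 4 the estimate is 4000 nM, with an expected range from 1000 nM to 20000 nM.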

Compound 4, half-maximal inhibitory concentration: 7000 nM
The estimate for compound 4 lay 1.8-fold (0.24 log units) below the measured number; measured number inside the range.
By their numbers in this assay, from the lowest: compound 3; then compound 4; then compound 1. At a limit, above all of these: compound 2.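

Going by these compounds alone, this is the first comparison of one ring with another on this aromatic carbon of the six-membered aromatic ring, and in this assay it shows that the assay distinguishes even the change from a three-membered to a four-membered non-aromatic ring of carbon only, with a 7.0-fold higher number from compound 3 to compound 4 (0.85 log units; beyond the scatter). Cyclobutyl nonetheless keeps compound 4 on the lower side of both open chains, with a 7.0-fold lower number from compound 1 to compound 4 (0.85 log units; beyond the scatter) for butyl and an at least 18-fold lower number from compound 2 to compound 4 (1.26 log units; beyond the scatter) for isobutyl, and the rise from cyclopropyl to cyclobutyl is printed at the same size as the fall from butyl to cyclobutyl, so a ring here does not by itself give the lowest number of the set. Compound 2 stands at a limit and not at a number, so its step gives only a bound: the limit of > 130000 nM in this assay, at which 1 of the 4 values shown sits.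

The compounds shown leave open whether a larger ring such as cyclopentyl would raise the number further, or whether a shorter open chain such as ethyl would lie closer to the rings than butyl does. They also leave open how an amine or a hydroxyl group at this same place would compare with cyclopropyl in this assay.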